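The source may report more compounds than this note shows. Statements on the series, on what has been measured and on what is new or still open speak of the compounds shown alone.

Measured compounds:
compound 1 `CC(C)(C)c1csc(N)c1C(=O)c1ccc(Cl)cc1`: 1%
compound 2 `CC(C)(C)Cc1c(-c2cccnc2)sc(N)c1C(=O)c1ccc(Cl)cc1`: 1%

In an assay on CHO cells for displacement of a labelled ligand from adenosine receptor A1 (Homo sapiens), read by scintillation counting, tested at 10 uM (on this read-out lower numbers stand for less inhibition and higher numbers for more inhibition at the one concentration tested (going by the name of the read-out)), compound 1 gives 1% and compound 2 gives 1%. For the measured compounds named here, compound 2 therefore stands level with compound 1 within the scatter, and no step between them can be drawn. Compound 3 `CC(C)(C)Cc1c(-c2c(F)cccc2F)sc(N)c1C(=O)c1ccc(Cl)cc1` differs from compound 2 in one place: 2,6-difluorophenyl in place of pyridin-3-yl on an aromatic carbon. With both measured compounds sitting at the floor of the read-out, no step beyond the scatter is expected. Compound 3 is expected to give 2%, with a range from 0% to 12%. The step this estimate means, a number 1 percentage points higher from compound 2 to compound 3 (within the scatter), is expected to stay within the scatter.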

Compound 3, a percentage reported as inhibition, at one concentration (the size of the read-out at that concentration, not a potency): 1%
For compound 3 the middle estimate is 1 percentage points above the measured one; measured number inside the range.
By their numbers in this assay, from the lowest: compounds 1, 2 and 3 (each within the scatter of the next).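

Placed on the aromatic carbon next to the ring sulfur, 2,6-difluorophenyl in place of pyridin-3-yl gives no change at the digits printed from compound 2 to compound 3 (within the scatter) in this assay. At this position, then, losing the ring nitrogen and its hydrogen-bond acceptor while gaining two fluorines does not move the reading out of the scatter, and both compounds remain close to the bottom of the scale. Nothing here explains this result. Still open, on these data alone, is whether a non-aromatic group at this position, such as an amine or a carboxylic acid, would give a clearly higher reading. Replacing the neopentyl group with a longer chain is equally untested by the compounds shown.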